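Chloro for acetyl at the meta position of the anilide

The source may hold more compounds than are shown below. What is called first, only, known or untested is meant among the compounds shown, and "the series" means these compounds.

Three measured compounds share one urea core and differ only in the group on the aniline ring: compound 1 `Cc1cccc(NC(=O)N[C@H](C)c2ccccc2)c1`, compound 2 `COc1cccc(NC(=O)N[C@H](C)c2ccccc2)c1` and compound 3 `CC(=O)c1cccc(NC(=O)N[C@H](C)c2ccccc2)c1`. In an ADME assay on the whole organism with Oryza sativa as the target, tested at 0.1 uM (on this read-out lower numbers stand for a stronger effect and higher numbers for a weaker effect at the one concentration tested), compound 1 gives 100%, compound 2 gives 104% and compound 3 gives 98%. All three stand together: the step of a number 2 percentage points lower from compound 1 to compound 3 (within the scatter) and the step of a number 6 percentage points lower from compound 2 to compound 3 (within the scatter) are both within the scatter, as is a number 4 percentage points higher from compound 1 to compound 2 (within the scatter), so compound 3 is indistinguishable from the other two on these numbers.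

Compound 4 `C[C@@H](NC(=O)Nc1cccc(Cl)c1)c1ccccc1` is still unmeasured. It differs from compound 3 in this way: chloro in place of acetyl on an aromatic carbon. Within the data shown here, the steps that bear on it are the two swaps at the same aromatic carbon, from compound 1 and from compound 2 to compound 3, and neither moved the read-out beyond the scatter. No step beyond the scatter is therefore expected in this assay for this further swap either; the step of a number 2 percentage points higher from compound 3 to compound 4 (within the scatter) is the estimate. Compound 4 is expected to give about 100%, between 90% and 110%.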

Compound 4, a percentage reported as activity, at one concentration (the size of the read-out at that concentration, not a potency): 97%
The estimate for compound 4 lay 3 percentage points above the measured number, and the stated range covers the measured number.
By their numbers in this assay, from the lowest: compounds 4, 3, 1 and 2 (each within the scatter of the next).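

In this assay, chloro in place of acetyl gives a number 1 percentage points lower from compound 3 to compound 4 (within the scatter), chloro in place of methoxy gives a number 7 percentage points lower from compound 2 to compound 4 (within the scatter), and chloro in place of methyl gives a number 3 percentage points lower from compound 1 to compound 4 (within the scatter). The aromatic carbon meta to a large group now holds a chlorine as well as groups built from carbon and oxygen, and all four compounds stand together on this read-out. The data offer no measurement that could account for this.

As far as these compounds go, it remains open whether an amine, a carboxylic acid or a longer chain at this place would stand with these four in this assay. It is equally open whether any group here can move the read-out at all, since every step among these compounds lies within the scatter.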